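Replacing a tert-butyl with cyano on the benzyl ring

The compounds below may be only part of what the source reports. "The series", "measured", "known", "first", "only" and "open" are said of these compounds alone.

Three hydroxamic acids sharing one core have been tested in a functional assay on MDA-MB-231 cells (Homo sapiens) for inhibition, read by sulforhodamine B assay; on this read-out lower numbers stand for stronger inhibition of growth and higher numbers for weaker inhibition of growth. Compound 1 `Cc1ccc(CN2CC=C(CCC(=O)NO)C2=O)cc1` gives 1990 nM, and compound 2 `O=C(CCC1=CCN(Cc2ccc(Cl)cc2)C1=O)NO` gives 1990 nM; the step of no change at the digits printed from compound 1 to compound 2 (within the scatter) shows that chloro in place of methyl on an aromatic carbon leaves the number where it was. Compound 3 `CC(C)(C)c1ccc(CN2CC=C(CCC(=O)NO)C2=O)cc1` gives 690 nM in this assay, the lowest of the three numbers, with a 2.9-fold lower number from compound 1 to compound 3 (0.46 log units; beyond the scatter) and a 2.9-fold lower number from compound 2 to compound 3 (0.46 log units; beyond the scatter) both beyond the scatter.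

Compound 4 `N#Cc1ccc(CN2CC=C(CCC(=O)NO)C2=O)cc1` differs from compound 3 by cyano in place of tert-butyl on an aromatic carbon. Among the compounds with values here, no measured step covers cyano itself; the steps that bear on it are a 2.9-fold lower number from compound 1 to compound 3 (0.46 log units; beyond the scatter) and a 2.9-fold lower number from compound 2 to compound 3 (0.46 log units; beyond the scatter), both of which show that putting tert-butyl in for a smaller group lowered the number modestly. Since the cyano group, like methyl and chloro, is smaller than tert-butyl, the step from compound 3 to compound 4 is expected to run the other way, back toward the numbers of compound 1 and compound 2.

Compound 4 is therefore estimated at 2000 nM in this assay, with a range from 800 nM to 5000 nM, which corresponds to an expected step of a 2.9-fold higher number from compound 3 to compound 4 (0.46 log units; beyond the scatter).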

Compound 4, concentration for 50% growth inhibition: 5380 nM
Compound 4: middle estimate off by 2.7-fold (0.43 log units), on the low side, outside the stated range (above it).
By their numbers in this assay, from the lowest: compound 3; then compounds 1 and 2 (each within the scatter of the next); then compound 4.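

At this position on the aromatic ring, cyano does not bring the number back to the level of methyl and chloro but carries it beyond that level: this assay gives a 7.8-fold higher number from compound 3 to compound 4 (0.89 log units; beyond the scatter), which is larger than the gap that separated tert-butyl from those two groups. Set against the other two compounds, the change gives a 2.7-fold higher number from compound 1 to compound 4 (0.43 log units; beyond the scatter) and a 2.7-fold higher number from compound 2 to compound 4 (0.43 log units; beyond the scatter), so the level shared by compound 1 and compound 2 is not a fixed level for every group other than tert-butyl, and the four compounds now fall on three levels, with compound 3 lowest, compound 1 and compound 2 together, and compound 4 highest. Nothing at hand explains why cyano parts from methyl and chloro in this way.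

On these data alone, whether the higher number belongs to cyano alone stays open, since a carboxylic acid, an amine or a methoxy group on the same carbon could fall with compound 4 or with compound 1 and compound 2. As far as these compounds go, it is also open whether a trifluoromethyl group or a longer alkyl chain in that place would follow compound 3.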